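From 3,4-Dihydroxyphenyl to 3,4-Dimethoxyphenyl on Compound 2

The source may hold more compounds than are shown below. What is called first, only, known or untested is meant among the compounds shown, and "the series" means these compounds.

In an ADME assay on HEK-293T cells (Homo sapiens) for cytotoxicity, read by CCK-8 assay, with a stated time of 48 h (a higher number here means a weaker inhibitor, a lower number a stronger inhibitor), compound 2 `O=C(Nc1cccc([N+](=O)[O-])c1)N1CCN(S(=O)(=O)c2sccc2-c2ccccc2Oc2ccc(O)c(O)c2)CC1` reads > 20000 nM which is a limit of the assay and not a number. Compound 3 `O=S(=O)(NCCNC(=S)Nc1cccc(Cl)c1)c1ccc(-c2ccccc2OCc2ccccc2)s1` gives 10200 nM as a true number. Compound 2 therefore stands at the limit of > 20000 nM in this assay, at which 2 of the 3 values shown sit, with no number of its own. Compound 4 `COc1ccc(Oc2ccccc2-c2ccsc2S(=O)(=O)N2CCN(C(=O)Nc3cccc([N+](=O)[O-])c3)CC2)cc1OC` differs from compound 2 in one place 3,4-dimethoxyphenyl in place of 3,4-dihydroxyphenyl on an oxygen on an aromatic ring where 3,4-dimethoxyphenyl takes the place of 3,4-dihydroxyphenyl on an oxygen on an aromatic ring. Compound 1 `COc1ccc(Oc2ccccc2-c2ccsc2S(=O)(=O)N2CCN(C(=S)Nc3ccc([N+](=O)[O-])cc3)CC2)cc1OC` also carries 3,4-dimethoxyphenyl and reads > 20000 nM as a limit too, so no step beyond the scatter is expected in this assay for this change. The expected move is a step that the limit leaves unreadable from compound 2 to compound 4 and no larger. Compound 4 is estimated at 25000 nM with an expected range of 12000 nM to 50000 nM and may well report only the same limit.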

Compound 4, half-maximal inhibitory concentration: > 20000 nM
Compound 4 gave a limit, no number; the forecaster's own chance of this, stated with the estimate: 80%; the middle value lies beyond the limit too.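

For the compounds shown here, compound 1, compound 2 and compound 4 each report only a limit in this assay, so no step from compound 1 or compound 2 to compound 4 can be read. The compounds shown leave open whether 3,4-dimethoxyphenyl in place of 3,4-dihydroxyphenyl changes the reading at all.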